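This account rests on a few compounds, and the source may have more. Where it says the series, first, only, none or still open, it means among the compounds named here.

Series notes, cytotoxicity track.

Compound 1 is `CC(C)(C)c1ccc(-c2nc(CN3CCC(C(=O)c4ccc5c(c4)OCCO5)CC3)co2)cc1` and compound 2 is `O=C(c1ccc2c(c1)OCCO2)C1CCN(Cc2coc(-c3cccnc3)n2)CC1`. In an ADME assay on HEK293 cells (Homo sapiens) for cytotoxicity, read by MTT assay, with a stated time of 36 h (on this read-out higher numbers stand for weaker inhibition and lower numbers for stronger inhibition), compound 1 gives > 150 ug/mL, which is a limit of the assay and not a number. In this assay compound 2 gives > 150 ug/mL, likewise a limit of the assay and not a number. The step that the two limits leave unreadable from compound 1 to compound 2 therefore cannot be read; the two compounds sit at the same limit, as summarised by the limit of > 150 ug/mL in this assay, at which 2 of the 2 values shown sit. Among the measured compounds shown here, compound 2 thus stands at the limit of this assay, with no measured number, and no measured step in the set tells how a change at the aromatic carbon bearing the outer ring moves the read-out.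

Compound 3 is `O=C(c1ccc2c(c1)OCCO2)C1CCN(Cc2coc(-c3ccco3)n2)CC1`, to be measured in this assay. It differs from compound 2 by furan-2-yl in place of pyridin-3-yl on an aromatic carbon. For the measured compounds named here, the only measured step on this carbon is the unreadable one from compound 1 to compound 2, so no size can be taken from it; the expectation is that compound 3 again reaches the limit and shows no step beyond the scatter. The expected step is a step that the limit leaves unreadable from compound 2 to compound 3. For compound 3 the estimate in this assay is 200 ug/mL, between 100 ug/mL and 400 ug/mL.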

Compound 3, half-maximal inhibitory concentration: > 150 ug/mL
Compound 3: only a limit was reported; the forecaster's own chance of this, stated with the estimate: 80%; the middle value is on the limit's open side.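

In this assay compound 3 gives > 150 ug/mL, a limit of the assay and not a number. Among the compounds shown here, no step among compound 1, compound 2 and compound 3 can be read, as all three sit at one limit: the limit of > 150 ug/mL in this assay, at which 3 of the 3 values shown sit. The compounds shown leave open how a change of the group on this aromatic carbon moves the read-out.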